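A few compounds are considered here, and "the series" means these few. Any claim that something is new, unique, unknown or untested is made for them only; others in the source may bear on it.

In a functional assay on Raji cells (Homo sapiens) for cytotoxicity, read by CCK-8 assay, with a stated time of 24 h (on this read-out lower numbers stand for stronger inhibition and higher numbers for weaker inhibition), compound 1 (`C=CC(=O)N1C(=O)CC(c2ccc(C)cc2)Sc2ccccc21`) gives 75500 nM and compound 2 (`C=CC(=O)N1C(=O)CC(c2ccc(Br)cc2)Sc2ccccc21`) gives 51300 nM, while compound 3 (`C=CC(=O)N1C(=O)CC(c2ccccc2C(F)(F)F)Sc2ccccc21`) gives 50300 nM and so stands within the scatter of both others. Compound 4 (`C=CC(=O)N1C(=O)CC(c2ccccc2)Sc2ccccc21`) has hydrogen in place of trifluoromethyl on an aromatic carbon and remains unmeasured. For the measured compounds named here, the one measured single-group step (a 1.5-fold lower number from compound 1 to compound 2 (0.17 log units; within the scatter)) puts bromo in place of methyl and stays within the scatter, but no measured compound carries hydrogen at the changed place, so it bears only indirectly. No step beyond the scatter is therefore expected in this assay, and the estimated step is a 1.2-fold higher number from compound 3 to compound 4 (0.08 log units; within the scatter) at most within that scatter. For compound 4 the estimated value is 60000 nM with an expected range from 35000 nM to 100000 nM on measurement.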

Compound 4, half-maximal inhibitory concentration: 74100 nM
The estimate for compound 4 lay 1.2-fold (0.09 log units) below the measured number; the measured number falls inside the stated range.
By their numbers in this assay, from the lowest: compounds 3, 2, 4 and 1 (each within the scatter of the next).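

In this assay, hydrogen in place of trifluoromethyl gives a 1.5-fold higher number from compound 3 to compound 4 (0.17 log units; within the scatter), hydrogen in place of bromo gives a 1.4-fold higher number from compound 2 to compound 4 (0.16 log units; within the scatter), and hydrogen in place of methyl gives a 1.0-fold lower number from compound 1 to compound 4 (0.01 log units; within the scatter). With hydrogen now measured, none of these three groups stands apart from it on this aromatic ring, as every step lies within the scatter. No measurement available here explains this closeness.

Still open, as far as these compounds go, is whether an amine or a carboxylic acid on this ring would give a step beyond the scatter.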